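The compounds below may be only part of what the source reports. "The series", "measured", "known", "first", "only" and "open" are said of these compounds alone.

In a functional assay (aorta) with Rattus norvegicus as the target (on this read-out lower numbers stand for an effect already at smaller amounts and higher numbers for an effect only at larger amounts of compound), the three measured compounds reach only the limits of the test. Compound 1 `Cc1ccccc1NC(=O)NC1CC(C)(C)Oc2ccc(F)cc21` gives > 30000 nM, a limit rather than a number. Compound 2 `Cc1ccccc1NC(=O)NC1CC(C)(C)Oc2ccc(Cl)cc21` gives > 10000 nM, again a limit. Compound 3 `CC1(C)CC(NC(=O)Nc2ccc(Cl)cc2)c2cc(F)ccc2O1` gives > 30000 nM, also a limit. Two of the values sit at the limit of > 30000 nM in this assay, at which 2 of the 3 values shown sit, and one at the limit of > 10000 nM in this assay, at which 1 of the 3 values shown sits, so the change chloro in place of fluoro on an aromatic carbon leaves a step that the two limits leave unreadable from compound 1 to compound 2, and the change 4-chlorophenyl in place of 2-methylphenyl on an amide-type nitrogen leaves a step that the two limits leave unreadable from compound 1 to compound 3. Compound 4 `CC1(C)CC(NC(=O)Nc2ccc(Cl)cc2)c2cc(Cl)ccc2O1` carries the same change as compound 2, namely (chloro in place of fluoro on an aromatic carbon), made on the core of compound 3. Since compound 3 stands at a limit with > 30000 nM and the matching step from compound 1 to compound 2 is not readable, the step for compound 4 is estimated as a number no higher from compound 3 to compound 4 (the limit leaves the size open). Compound 4 is therefore expected to give about 30000 nM, most likely again as a limit.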

Compound 4, half-maximal effective concentration: > 300000 nM
Compound 4: no number, only a limit; the forecaster's own chance of this, stated with the estimate: 85%; middle value at least 10-fold (1.00 log units) away from the limit.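

Compound 4 also gives only a limit, not a number, so its steps from compound 3 and from compound 2 cannot be read. The compounds shown leave open at what concentration any of the four acts, and whether chloro or fluoro makes any difference.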